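A Second Carboxylic Acid on an Unreadable Glycoside Series

The compounds below may be only part of what the source reports. "The series", "measured", "known", "first", "only" and "open" are said of these compounds alone.

Compound 1 `C/C=C1/[C@H](O[C@@H]2O[C@H](CO)[C@@H](O)[C@H](O)[C@H]2O)OC=C(C(=O)OC)[C@H]1CC(=O)OCCc1ccc(O)cc1`, compound 2 `C/C=C1/[C@H](O[C@@H]2O[C@H](CO)[C@@H](O)[C@H](O)[C@H]2O)OC=C(C(=O)OC)[C@H]1CC(=O)NCCC` and compound 3 `C/C=C1/[C@H](O[C@@H]2O[C@H](CO)[C@@H](O)[C@H](O)[C@H]2O)OC=C(C(=O)OC)[C@H]1CC(=O)O` share one core and differ only in the group carried on the side-chain carbonyl. In a functional assay on SK-BR-3 cells (Homo sapiens) for antiproliferative activity, read by MTT assay, with a stated time of 72 h (a lower number here means a stronger inhibitor, a higher number a weaker inhibitor), compound 1 reaches only a limit, > 20000 nM. Compound 2 likewise gives only a limit, > 20000 nM. Compound 3 too stands at a limit, > 15000 nM. The steps among them, a step that the two limits leave unreadable from compound 1 to compound 2, a step that the two limits leave unreadable from compound 1 to compound 3 and a step that the two limits leave unreadable from compound 2 to compound 3, are therefore of unreadable size: all three values rest at the limit of > 15000 nM in this assay, at which 1 of the 3 values shown sits, or (the limit of > 20000 nM in this assay, at which 2 of the 3 values shown sit), so nothing about the side chain can be ranked. Compound 4 `C/C=C1/[C@H](O[C@@H]2O[C@H](CO)[C@@H](O)[C@H](O)[C@H]2O)OC=C(C(=O)O)[C@H]1CC(=O)O` follows from compound 3 by hydrogen in place of methyl on an oxygen next to a carbonyl group. Going by the values given here, no measured step bears on this change with a readable size, as every known compound sits at a limit. The step from compound 3 to compound 4 is therefore expected as a step that the limit leaves unreadable from compound 3 to compound 4, which amounts to no readable movement. Compound 4 is expected to give about 30000 nM, between 15000 nM and 100000 nM, and most likely to be reported once more as a limit in this assay.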

Compound 4, half-maximal inhibitory concentration: > 50000 nM
Compound 4 ended at the assay's limit; the forecaster's own chance of this, stated with the estimate: 90%; at least 1.6-fold (0.22 log units) between middle value and limit.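

In this assay compound 4 gives only a limit, > 50000 nM. Compound 3 also rests at a limit, so the change from methoxycarbonyl to carboxy between compound 3 and compound 4 cannot be read. The compounds shown leave open whether any change on the shared core would give a measurable value.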